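From 4-hydroxycyclohexyl to cyclopropylmethyl on an aromatic nitrogen

The compounds below may be only part of what the source reports. "The series", "measured", "known", "first", "only" and "open" are said of these compounds alone.

Compound 2 (`CN1CCN(c2ccc(Nc3ncc4nc([S+]([O-])c5ccccc5)n([C@H]5CC[C@H](O)CC5)c4n3)cc2)CC1`) gives 268 nM in a functional assay on HCC827 cells (Homo sapiens) for antiproliferative activity, read by MTT assay, with a stated time of 72 h (a lower number here means a stronger inhibitor, a higher number a weaker inhibitor), and compound 1 (`CC(C)n1c(Sc2ccccc2)nc2cnc(Nc3ccc(N4CCN(C)CC4)cc3)nc21`) gives 290 nM there, two values that lie within the scatter of repeated measurements, so neither can be ranked over the other. For compound 3 (`CN1CCN(c2ccc(Nc3ncc4nc([S+]([O-])Cc5cccnc5)n(C5CCOCC5)c4n3)cc2)CC1`) the reading of > 10000 nM is a limit of the assay and not a number.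

Compound 4 (`CN1CCN(c2ccc(Nc3ncc4nc([S+]([O-])c5ccccc5)n(CC5CC5)c4n3)cc2)CC1`), not yet measured, has cyclopropylmethyl in place of 4-hydroxycyclohexyl on an aromatic nitrogen. The rest of the molecule stays the same. Among the compounds with values here, no measured pair shows this swap alone, so any expectation in this assay is loose. Starting from compound 2 at 268 nM the number is expected to rise modestly, which would mean a somewhat weaker inhibitor. The expected size is a 2.2-fold higher number from compound 2 to compound 4 (0.35 log units; beyond the scatter) by this estimate. For compound 4 the estimate is 600 nM with an expected range from 150 nM to 2400 nM in this measurement.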

Compound 4, half-maximal inhibitory concentration: 838 nM
Beside the measured number, compound 4's estimate is 1.4-fold (0.15 log units) below it, within the range that was stated.
By their numbers in this assay, from the lowest: compounds 2 and 1 (each within the scatter of the next); then compound 4. At a limit, above all of these: compound 3.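

Within the data shown here, this is the only pair here that differs in one place, so the group on this aromatic nitrogen can finally be judged on its own. In this assay, cyclopropylmethyl in place of 4-hydroxycyclohexyl gives a 3.1-fold higher number from compound 2 to compound 4 (0.50 log units; beyond the scatter) and so shows that the number responds to this group, although the change is modest and the inhibitor is weaker but still measurable. The swap alters the ring, the heavy-atom count and the hydrogen-bond donor and acceptor counts all at once, and nothing measured here separates these changes or explains the step.

Going by these compounds, it remains open whether the hydroxyl itself matters or the six-membered ring does. A plain cyclohexyl group or a 4-aminocyclohexyl group at this position could begin to separate the two.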